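Cyclopentyl for fluorophenyl on a tetrahydropyran series

A few compounds are considered here, and "the series" means these few. Any claim that something is new, unique, unknown or untested is made for them only; others in the source may bear on it.

Measured so far:
compound 1 `COc1ccc(/C=C/C[C@@H]2C[C@H]([C@H](O)c3ccc(OC)c(OC)c3)CO[C@H]2c2ccc(OC)c(OC)c2)cc1OC` — "not determined" (no result reported)
compound 2 `O[C@@H](c1ccccc1)[C@H]1CO[C@H](c2ccccc2)[C@@H](C/C=C/c2cccc(F)c2)C1` — 9170 nM
compound 3 `COc1ccc(/C=C/C[C@H]2C[C@@H]([C@@H](O)c3ccc(OC)c(OC)c3)CO[C@@H]2c2ccc(OC)c(OC)c2)cc1OC` — 34700 nM

In a functional assay on HL-60 cells (Homo sapiens) for cytotoxicity, read by WST assay, with a stated time of 48 h (a higher number here means a weaker inhibitor, a lower number a stronger inhibitor), compound 2 gives the lowest of the two reported numbers, and compound 3 stands 34700 nM, a gap beyond the usual scatter. Compound 1 has no result in this assay; compounds 1 and 3 are related by the fact that compounds 1 and 3 differ only in the configuration as drawn. Compound 4 `O[C@@H](c1ccccc1)[C@H]1CO[C@H](c2ccccc2)[C@@H](C/C=C/C2CCCC2)C1` is not yet measured. It differs from compound 2 in one place: cyclopentyl in place of 3-fluorophenyl on a double-bonded chain carbon bound to a double-bonded chain carbon. For the measured compounds named here, no measured step of this kind is available, so the expectation rests on compound 2 alone. The step from compound 2 to compound 4 is expected to stay within the scatter, a 1.3-fold higher number from compound 2 to compound 4 (0.12 log units; within the scatter), with no clear direction. Compound 4 is therefore estimated at 12000 nM, in a range from 4000 nM to 40000 nM.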

Compound 4, half-maximal inhibitory concentration: 9060 nM
Estimate against measurement, compound 4: 1.3-fold (0.12 log units) above, and the stated range covers the measured number.
By their numbers in this assay, from the lowest: compounds 4 and 2 (each within the scatter of the next); then compound 3.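

Exchanging 3-fluorophenyl for cyclopentyl gives a 1.0-fold lower number from compound 2 to compound 4 (0.01 log units; within the scatter) in this assay and so leaves the read-out unchanged. At this place, then, a five-membered non-aromatic carbon ring and a fluorinated six-membered aromatic ring are not told apart by this measurement. Nothing available bears on why the two compounds read alike.

On these data alone, whether an amine, a carboxylic acid or a longer chain at this place would read the same remains open. So does whether the same exchange would behave alike on the core of compound 3.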